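Free acid to (2-chlorophenyl)amide: series working notes

This account rests on a few compounds, and the source may have more. Where it says the series, first, only, none or still open, it means among the compounds named here.

Within the data shown here, in a functional assay on KB cells (Homo sapiens) for inhibition, read by MTT assay, with a stated time of 24 h, tested at 0.1 ug/mL (a higher number here means more inhibition of growth at the concentration tested, a lower number less inhibition of growth), compound 1 `CC(=O)SCCC(CCCCC(=O)O)SC(C)=O` gives 7.24%, the only number available in this small series. Compound 2 `O=C(CCCCC(S)CCS)Nc1cccc(Cl)c1` is recorded as "not active" (no number reported). Compound 3 `O=C(CCCCC(S)CCS)Nc1cccc2ccccc12` is also recorded as "not active" (no number reported). Neither of these entries carries a number, so compound 1 cannot be ranked numerically against them.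

Compound 4 `CC(=O)SCCC(CCCCC(=O)Nc1ccccc1Cl)SC(C)=O` keeps the core of compound 1 and differs from it in one place: (2-chlorophenyl)amino in place of hydroxy on a carbonyl carbon. In words, (2-chlorophenyl)amino replaces hydroxy on a carbonyl carbon. Among the measured compounds shown here, no measured step shows the effect of such a replacement, so the expectation is loose and rests mainly on compound 1 at 7.24%. A step within the scatter, with no firm direction, is expected, and the estimated step is a number 2.8 percentage points higher from compound 1 to compound 4 (within the scatter). A report without a number also remains possible. The estimated value for compound 4 is 10%, with an expected range from 0% to 30%.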

Compound 4, percent growth inhibition at one concentration: 7.05%
For compound 4 the middle estimate is 3 percentage points above the measured one; the measured number falls inside the stated range.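

In this assay, among these compounds, the step of a number 0.2 percentage points lower from compound 1 to compound 4 (within the scatter) is the first reading at this place with a number at both ends, and it comes from (2-chlorophenyl)amino in place of hydroxy on a carbonyl carbon. For this pair, the free acid is therefore not needed for a reading of this size, even though the entering group brings eight heavy atoms and a six-membered aromatic ring where a single oxygen stood. Nothing available explains why the two readings lie within the scatter of each other, and the data give no cause for it.

Whether the chlorine contributes to the reading stays open, since a plain phenylamino group on the same carbonyl carbon is not among the compounds shown. The same holds for a methoxy group or a simple amine at this place, so the tolerance seen rests on a single pair at one tested concentration.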